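The source may report more compounds than this note shows. Statements on the series, on what has been measured and on what is new or still open speak of the compounds shown alone.

Measured so far:
compound 1, `O=C(NCc1ccc(C(F)(F)F)nc1N1CCC(Cc2ccccc2)CC1)Nc1cccc2c(=O)[nH]ccc12`: 5.81 nM
compound 2, `CCCCOc1nc(C(F)(F)F)ccc1CNC(=O)Nc1cccc2c(=O)[nH]ccc12`: 160 nM

Both numbers come from an assay on CHO cells for agonist activity at transient receptor potential cation channel subfamily V member 1 (Homo sapiens); on this read-out higher numbers stand for an effect only at larger amounts of compound and lower numbers for an effect already at smaller amounts. Compound 2 stands at the highest of the two values; the nearest is compound 1, whose number is lower by a margin that goes beyond the usual scatter. Compound 3, `CC(C)c1cccc(-c2nc(C(F)(F)F)ccc2CNC(=O)Nc2cccc3c(=O)[nH]ccc23)c1`, has not yet been measured in this assay. It differs from compound 2 in one place: 3-isopropylphenyl in place of butoxy on an aromatic carbon. Within the data shown here, no step between measured compounds that differ in one place is available, so the size of this step can only be guessed. Compound 1 gives 5.81 nM, a lower number than compound 2, and the change to compound 3 also enlarges the group in that place; the step from compound 2 to compound 3 is therefore expected to run toward lower numbers, a 5.3-fold lower number from compound 2 to compound 3 (0.73 log units; beyond the scatter). For compound 3 the expected value in this assay is 30 nM, with a likely range from 8 nM to 120 nM.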

Compound 3, half-maximal effective concentration: 3.07 nM
Compound 3: the middle estimate sits 9.8-fold (0.99 log units) above what was measured, and the stated range ends above it.
By their numbers in this assay, from the lowest: compounds 3 and 1 (each within the scatter of the next); then compound 2.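

In this assay, putting 3-isopropylphenyl in place of butoxy on the aromatic carbon next to the ring nitrogen gives a 52-fold lower number from compound 2 to compound 3 (1.72 log units; beyond the scatter) as a large change, so this one position can move the number strongly. Compound 3 (at 3.07 nM) and compound 1 (at 5.81 nM) lie within the scatter of each other, so two different large groups in this place give matching numbers here. Nothing measured here explains the step, and the data cannot separate the arrival of the ring from the loss of butoxy.

Going by these compounds, it remains open whether the isopropyl contributes anything, or whether the ring alone would give the same number. A plain phenyl, a morpholine or a carboxylic acid in this place would help to settle how much the group's nature matters.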